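A few compounds are considered here, and "the series" means these few. Any claim that something is new, unique, unknown or untested is made for them only; others in the source may bear on it.

Measured compounds:
- compound 1, `O=C(NCc1ccc(S(=O)(=O)c2ccccc2)cc1)c1cc2ncccc2s1`: 400 nM
- compound 2, `CC(NC(=O)c1cc2cnccc2[nH]1)c1ccc(S(=O)(=O)N2CCCCC2)cc1`: > 10000 nM

Among the compounds with values here, in an assay for inhibition of Nicotinamide phosphoribosyltransferase (Homo sapiens), read by mass spectrometry, with stated times of 15 min and 30 min (on this read-out higher numbers stand for weaker inhibition and lower numbers for stronger inhibition), compound 1 gives 400 nM, the only full number among the values shown. For compound 2 this assay returns only a limit, > 10000 nM, so no number is known for it; this is the limit of > 10000 nM in this assay, at which 1 of the 2 values shown sits. Within the data shown here, compound 1 therefore stands alone as the one compound with a measured strength, and the two compounds differ in more than one place, so nothing can be said about any single change between them.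

Compound 3, `O=C(NCc1ccc(S(=O)(=O)c2ccccc2)cc1)c1cnc2nccn2c1`, is not yet measured. It differs from compound 1 in one place: a group of 9 heavy atoms (6 carbon, 3 nitrogen; one five-membered aromatic ring with 2 hetero atoms, one six-membered aromatic ring with 2 hetero atoms) in place of a group of 9 heavy atoms (7 carbon, 1 nitrogen, 1 sulfur; one five-membered aromatic ring with 1 hetero atom, one six-membered aromatic ring with 1 hetero atom), on a carbonyl carbon. Among the measured compounds shown here, no measured pair here shows the effect of such a swap of ring systems, so there is no measured step to lean on. The expectation is a step from compound 1 to compound 3 of no change at the digits printed from compound 1 to compound 3 (within the scatter) in this assay, that is, no change beyond the usual scatter. Compound 3 is estimated at 400 nM, with a range from 80 nM to 2500 nM.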

Compound 3, half-maximal inhibitory concentration: 2 nM
Estimate against measurement, compound 3: 200-fold (2.30 log units) above; the whole stated range lies above it.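

Within the data shown here, this pair is the first single change that can be read, and it shows that the group on the carbonyl carbon strongly affects the result in this assay: with the rest of the molecule unchanged, the swap of ring systems gives a 200-fold lower number from compound 1 to compound 3 (2.30 log units; beyond the scatter). Both groups have 9 heavy atoms and no hydrogen-bond donor, so the step comes without a change in either count, while the entering group has 3 nitrogen and no sulfur. No measurement shown here explains why this swap has so large an effect.

On these data alone, it remains open which nitrogen or ring of the entering group matters most. It is also unknown whether a smaller group on the carbonyl carbon, such as a single pyridine ring, would give a similar result.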